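Amide to Urea: What to Expect for Compound 3

This account rests on a few compounds, and the source may have more. Where it says the series, first, only, none or still open, it means among the compounds named here.

Measured compounds:
compound 1: `O=C(Nc1cccc(-n2cc(-c3ccncc3)c(-c3ccc(Cl)c(O)c3)n2)c1)Nc1ccc(Cl)c(Cl)c1` — 2640 nM
compound 2: `COc1cc(-c2nn(-c3cccc(NC(=O)c4ccc(Cl)c(C(F)(F)F)c4)c3)cc2-c2ccncc2)ccc1Cl` — 19700 nM

In a functional assay on SK-MEL-2 cells (Homo sapiens) for inhibition, read by sulforhodamine B assay, with a stated time of 48 h (a lower number here means a stronger inhibitor of growth, a higher number a weaker inhibitor of growth), compound 1 gives 2640 nM, and compound 2 gives 19700 nM. Compound 2 stands with the highest number of the two; its nearest neighbour, compound 1, sits well below it, a gap beyond the scatter.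

Compound 3, `COc1cc(-c2nn(-c3cccc(NC(=O)Nc4cccc(C(F)(F)F)c4)c3)cc2-c2ccncc2)ccc1Cl`, has not yet been measured. It differs from compound 2 in a single place: (3-(trifluoromethyl)phenyl)amino in place of 4-chloro-3-(trifluoromethyl)phenyl on a carbonyl carbon. With this change the carbonyl carbon of compound 3 carries an amino group in the same way as the carbonyl carbon of compound 1 does.

Among the compounds with values here, no step between measured compounds shows this exact change, so any expectation rests on what the two measured compounds show. Compound 1, the one whose carbonyl carbon carries an amino group, has the lower number, 2640 nM. The step of a 3.9-fold lower number from compound 2 to compound 3 (0.60 log units; beyond the scatter) is therefore expected to run downward, by an amount beyond the scatter, though short of matching compound 1. Compound 3 is expected to give about 5000 nM, within a range from 1500 nM to 16000 nM.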

Compound 3, concentration for total growth inhibition: 1960 nM
For compound 3 the middle estimate is 2.6-fold (0.41 log units) above the measured one; low and high end bracket the measured number.
By their numbers in this assay, from the lowest: compounds 3 and 1 (each within the scatter of the next); then compound 2.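

In this assay, the group on this carbonyl carbon proves to matter: replacing 4-chloro-3-(trifluoromethyl)phenyl with (3-(trifluoromethyl)phenyl)amino gives a 10-fold lower number from compound 2 to compound 3 (1.00 log units; beyond the scatter). Within the data shown here, this is the first step that differs in one place, so the size of a change at this carbonyl carbon can now be read directly rather than inferred from two compounds that also differ elsewhere. No measurement available here accounts for the step, which therefore stands as an observation without an explanation.

The swap makes two alterations at once, since the entering group carries a nitrogen and a hydrogen-bond donor while the leaving group carries a chlorine, and the compounds shown do not separate the share of each in the step. On these data alone, a (4-chloro-3-(trifluoromethyl)phenyl)amino group on this same carbonyl carbon would keep the chlorine while adding the nitrogen, and a methylamino-linked version of the (3-(trifluoromethyl)phenyl) group, with a methyl in place of the amino hydrogen, would keep that nitrogen while removing the donor, so both questions remain open.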